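Amino in place of nitro: working notes on the series

This account rests on a few compounds, and the source may have more. Where it says the series, first, only, none or still open, it means among the compounds named here.

Measured in a functional assay on SK-MEL cells (Homo sapiens) for cytotoxicity, read by MTT assay, with a stated time of 6 days; on this read-out higher numbers stand for an effect only at larger amounts of compound and lower numbers for an effect already at smaller amounts:
compound 1 `COC(=O)c1c(-c2ccc(O)cc2)oc2ccccc2c1=O`: > 25 ug/mL
compound 2 `O=c1cc(-c2ccc([N+](=O)[O-])cc2)oc2cc(O)ccc12`: > 25 ug/mL
compound 3 `O=c1cc(-c2ccc([N+](=O)[O-])cc2)oc2c(O)c(O)ccc12`: 3.29 ug/mL

Compound 2 gives no number here, only the limit > 25 ug/mL. Compound 1 likewise gives only a limit, > 25 ug/mL. Within the data shown here, the series so far therefore rests largely on (the limit of > 25 ug/mL in this assay, at which 2 of the 3 values shown sit).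

Compound 4 `Nc1ccc(-c2cc(=O)c3ccc(O)cc3o2)cc1` is still unmeasured. Its difference from compound 2 is amino in place of nitro on an aromatic carbon, para to a large group.

Among the measured compounds shown here, only one measured step is available, and it is a different change, hydroxy in place of hydrogen on an aromatic carbon. It is an at least 7.5-fold lower number from compound 2 to compound 3 (0.88 log units; beyond the scatter), and compound 3 reads 3.29 ug/mL. For the measured compounds named here, that step shows that the read-out can leave the limit towards lower numbers, but it gives no size for replacing nitro, and no measured step makes that replacement. No step beyond the scatter is therefore expected in this assay, though a move to lower numbers cannot be excluded. The expected change is a number no higher from compound 2 to compound 4 (the limit leaves the size open). For compound 4 the estimated value is 25 ug/mL, with an expected range from 8 ug/mL to 50 ug/mL.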

Compound 4, concentration for half-maximal effect: 6.59 ug/mL
Compound 4: middle estimate off by 3.8-fold (0.58 log units), on the high side, and the stated range ends above it.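

In this assay, amino in place of nitro on an aromatic carbon, para to a large group, gives an at least 3.7-fold lower number from compound 2 to compound 4 (0.57 log units; beyond the scatter), so a change at this place alone is enough to bring the read-out off the limit. The earlier compounds shown here showed such a move only through an added hydroxy with the nitro kept, whereas the hydroxy pattern of compound 2 is kept in compound 4, which still gives a measured number, 6.59 ug/mL. The size of this step remains a lower bound, with the starting point of compound 2 being a limit and not a number: the limit of > 25 ug/mL in this assay, at which 2 of the 4 values shown sit.

On these data alone, whether the move to lower numbers belongs to the amino group itself or would also come with another group at this place, such as a dimethylamino group, an acetamide or a carboxylic acid, stays open, as does what a plain hydrogen there would give. Also open, as far as these compounds go, is whether amino and the added hydroxy of compound 3, brought together on the shared core, would move the number further than either change alone.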